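The compounds below may be only part of what the source reports. "The series", "measured", "known", "first", "only" and "open" are said of these compounds alone.

Compound 1 `COc1ccc2c(=O)c(-c3cc(OC)c(OC)cc3OC)coc2c1` gives 2640 nM in a functional assay on A-375 cells (Homo sapiens) for antiproliferative activity, read by MTT assay, with a stated time of 24 h; a lower number here means a stronger inhibitor, a higher number a weaker inhibitor. In this assay compound 2 `COc1cc(OC)c(-c2coc3cc(OCc4ccc(Br)cc4)ccc3c2=O)cc1OC` gives 1000 nM, and compound 3 `COc1cc(OC)c(-c2coc3cc(OCc4ccc(C#N)cc4)ccc3c2=O)cc1OC` gives 1550 nM. Within the data shown here, compound 2 therefore has the lowest of the three numbers, though only one step separates it clearly from the rest: a 1.6-fold higher number from compound 2 to compound 3 (0.19 log units; within the scatter) lies within the scatter, whereas a 2.6-fold lower number from compound 1 to compound 2 (0.42 log units; beyond the scatter) lies beyond it.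

Compound 4 `COc1cc(OC)c(-c2coc3cc(OCc4cccc(Br)c4)ccc3c2=O)cc1OC` keeps every atom of compound 2 and differs only in how they are joined: 3-bromophenyl in place of 4-bromophenyl on a saturated chain carbon bound to an oxygen on an aromatic ring. Among the measured compounds shown here, no measured step moves the bromine around the ring, so none bears on this change directly. What the measured steps do show is that attaching a substituted benzyl group lowers the number, with a 2.6-fold lower number from compound 1 to compound 2 (0.42 log units; beyond the scatter) beyond the scatter and a 1.7-fold lower number from compound 1 to compound 3 (0.23 log units; within the scatter) within it, and that exchanging the group on that ring, as in a 1.6-fold higher number from compound 2 to compound 3 (0.19 log units; within the scatter), stays within the scatter. On that basis the account expects no step beyond the scatter in this assay, with a 1.2-fold higher number from compound 2 to compound 4 (0.08 log units; within the scatter) being the estimated shift. Compound 4 is thus estimated at 1200 nM, with a range from 600 nM to 2500 nM.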

Compound 4, half-maximal inhibitory concentration: 1120 nM
The estimate for compound 4 lay 1.1-fold (0.03 log units) above the measured number, and the stated range covers the measured number.
By their numbers in this assay, from the lowest: compounds 2, 4, 3 and 1 (each within the scatter of the next, the first and the last beyond it).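

Among these compounds, compound 4 gives the first direct reading of this change, and in this assay the 4-bromophenyl and 3-bromophenyl groups on the saturated chain carbon cannot be told apart (a 1.1-fold higher number from compound 2 to compound 4 (0.05 log units; within the scatter)). Compound 4 also stays within the scatter of the 4-cyanophenyl compound (a 1.4-fold lower number from compound 3 to compound 4 (0.14 log units; within the scatter)), but its separation from the unbenzylated compound (a 2.4-fold lower number from compound 1 to compound 4 (0.37 log units; beyond the scatter)) lies beyond the scatter, so both bromobenzyl compounds now clear that line while compound 3 remains the exception. No independent evidence is available here to explain these numbers.

As far as these compounds go, whether a longer chain such as 2-phenylethyl in place of the benzyl group, or an amine or a carboxylic acid on the aromatic ring, would move the number beyond the scatter of compound 2 remains open. The compounds shown also leave open whether the close agreement between compound 2 and compound 4 would hold with chloro or methoxy in place of bromo.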